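The source may report more compounds than this note shows. Statements on the series, on what has been measured and on what is new or still open speak of the compounds shown alone.

Measured in a functional assay on THP-1 cells (Homo sapiens) for inhibition; on this read-out lower numbers stand for stronger inhibition and higher numbers for weaker inhibition:

- Compound 1 `O=C1C[C@H](NC(=O)[C@@H]2CNC[C@@H]3CCCC[C@H](NC(=O)c4nccc5ccccc45)C(=O)N32)C(O)O1`: 156 nM
- Compound 2 `CN1C[C@@H]2CCCC[C@H](NC(=O)c3ccccc3)C(=O)N2[C@H](C(=O)N[C@H]2CC(=O)OC2O)C1`: 1820 nM
- Compound 3 `O=C1C[C@H](NC(=O)[C@@H]2COC[C@@H]3CCCC[C@H](NC(=O)c4cc5ccccc5s4)C(=O)N32)C(O)O1`: 178 nM

Compound 2, at 1820 nM, has the highest number of the three and so is the weakest inhibitor so far. Compound 3 and compound 1 both lie well below it, beyond the scatter.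

The next compound to be tested is compound 4 `O=C1C[C@H](NC(=O)[C@@H]2CNC[C@@H]3CCCC[C@H](NC(=O)c4ccccc4)C(=O)N32)C(O)O1`. It differs from compound 2 by one change: hydrogen in place of methyl on an amine nitrogen in a ring, with hydrogen in place of methyl on an amine nitrogen in a ring. Compound 1 also carries hydrogen on that ring nitrogen, but it differs from compound 4 elsewhere as well. Within the data shown here, no measured pair therefore shows this change alone, and the low number of compound 1 cannot be credited to it.

Among the measured compounds shown here, with no such pair to draw on, the expectation starts from compound 2 at 1820 nM, and only a small move in this assay is foreseen. The estimate means a 1.2-fold lower number from compound 2 to compound 4 (0.08 log units; within the scatter), an expected step toward a slightly lower number that stays within the scatter. For compound 4 the estimated value is 1500 nM, with an expected range of 500 nM to 4500 nM.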

Compound 4, half-maximal inhibitory concentration: 245 nM
Compound 4: the middle estimate sits 6.1-fold (0.79 log units) above what was measured; measured number outside the range, below it.
By their numbers in this assay, from the lowest: compounds 1, 3 and 4 (each within the scatter of the next); then compound 2.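

In this assay, among these compounds, hydrogen in place of methyl on the amine nitrogen in the six-membered ring gives a 7.4-fold lower number from compound 2 to compound 4 (0.87 log units; beyond the scatter), the first single change in this set to move the number beyond the scatter, so this ring nitrogen is a position that matters in this assay. The second pair, read with hydrogen on that same nitrogen, shows that phenyl in place of isoquinolin-1-yl on a carbonyl carbon gives a 1.6-fold higher number from compound 1 to compound 4 (0.20 log units; within the scatter), which is within the scatter, so the isoquinolin-1-yl group is not needed for a number in this range. Nothing measured here bears on the reason for either step.

Among the compounds shown here, the methyl step is seen only with the phenyl group in place, so whether methyl on this nitrogen has a similar effect alongside isoquinolin-1-yl remains open. Going by these compounds, it is also open how the nitrogen would respond to groups other than hydrogen and methyl, such as an ethyl or an acetyl group, since only these two are compared at this position.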